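Bromobenzyl triazole chalcones in A549 growth inhibition

The compounds below may be only part of what the source reports. "The series", "measured", "known", "first", "only" and "open" are said of these compounds alone.

Compound 1 `COc1ccc(C(=O)/C=C/c2ccc(OCc3cn(Cc4ccccc4Br)nn3)cc2)cc1` and compound 2 `COc1ccc(C(=O)/C=C/c2ccc(OCc3cn(Cc4cccc(Br)c4)nn3)cc2)cc1` share one core and differ by 3-bromophenyl in place of 2-bromophenyl on a saturated chain carbon bound to an aromatic nitrogen. In a functional assay on A549 cells (Homo sapiens) for inhibition, read by MTT assay, with a stated time of 48 h, tested at 10 uM (a higher number here means more inhibition of growth at the concentration tested, a lower number less inhibition of growth), compound 1 gives 52%, and compound 2 gives 47%; a number 5 percentage points lower from compound 1 to compound 2 (within the scatter). Compound 3 `O=C(/C=C/c1ccc(OCc2cn(Cc3ccccc3Br)nn2)cc1)c1ccc([N+](=O)[O-])cc1` sits on a second core, set apart from compound 1 by nitro in place of methoxy on an aromatic carbon. In this assay compound 3 gives 42%, and a number 10 percentage points lower from compound 1 to compound 3 (within the scatter). Compound 4 `O=C(/C=C/c1ccc(OCc2cn(Cc3cccc(Br)c3)nn2)cc1)c1ccc([N+](=O)[O-])cc1` has not been measured; it differs from compound 3 by 3-bromophenyl in place of 2-bromophenyl on a saturated chain carbon bound to an aromatic nitrogen, the same change as between compound 1 and compound 2, at a place described in identical words for both pairs. The step expected from compound 3 to compound 4 is a number 4 percentage points lower from compound 3 to compound 4 (within the scatter), about the size of the earlier one. Going by the values given here, this expectation rests on the single measured instance of the change, because a number 5 percentage points lower from compound 1 to compound 2 (within the scatter). Compound 4 is therefore estimated at 38%, within 26% to 50%.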

Compound 4, percent growth inhibition at one concentration: 28%
Compound 4: the middle estimate sits 10 percentage points above what was measured; the measured number falls inside the stated range.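

In this assay the change from 2-bromobenzyl to 3-bromobenzyl, carried onto the core of compound 3, gives a number 14 percentage points lower from compound 3 to compound 4 (beyond the scatter), and this agrees with the step on the first core: the same change on two cores in this assay, a number 5 percentage points lower (within the scatter) from compound 1 to compound 2 and a number 14 percentage points lower (beyond the scatter) from compound 3 to compound 4, 9 percentage points apart, within the scatter of two such steps. Nitro in place of methoxy, carried onto the core of compound 2, gives a number 19 percentage points lower from compound 2 to compound 4 (beyond the scatter), and the comparison with the earlier step reads the same: the same change on two cores in this assay, a number 10 percentage points lower (within the scatter) from compound 1 to compound 3 and a number 19 percentage points lower (beyond the scatter) from compound 2 to compound 4, 9 percentage points apart, within the scatter of two such steps. Neither change is thus seen to differ from one core to the other, but with one pair per change this does not show that the steps are equal, only that the gap between them cannot be told from scatter.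

The compounds shown leave open how an amine or a carboxylic acid in place of methoxy or nitro would fit this picture. Also open, from the compounds shown here alone, is whether the steps would hold with a plain benzyl or a longer chain in place of the bromobenzyl group.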